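A few compounds are considered here, and "the series" means these few. Any claim that something is new, unique, unknown or untested is made for them only; others in the source may bear on it.

In a functional assay on MCF7 cells (Homo sapiens) for cytotoxicity, read by sulforhodamine B assay, with a stated time of 24 h (on this read-out higher numbers stand for weaker inhibition and lower numbers for stronger inhibition), the three measured compounds sit close together. Compound 1 `N/N=C1\C(=O)Nc2ccc(S(=O)(=O)N3CCOCC3)cc21` gives 46800 nM, compound 2 `O=C1Nc2ccc(S(=O)(=O)N3CCOCC3)cc2/C1=N/c1ccc(O)cc1` gives 52700 nM, and compound 3 `CC(=O)c1cccc(/N=C2\C(=O)Nc3ccc(S(=O)(=O)N4CCOCC4)cc32)c1` gives 39200 nM, the lowest of the three numbers, though its gaps to compound 1 and to compound 2 both lie within the scatter. Compound 4 `O=C1Nc2ccc(S(=O)(=O)N3CCOCC3)cc2/C1=N/c1ccc(Br)cc1` differs from compound 3 in one place: 4-bromophenyl in place of 3-acetylphenyl on a double-bonded nitrogen. Every measured step swaps the group on the double-bonded nitrogen, and none reaches beyond the scatter: a 1.2-fold lower number from compound 1 to compound 3 (0.08 log units; within the scatter), a 1.3-fold lower number from compound 2 to compound 3 (0.13 log units; within the scatter) and a 1.1-fold higher number from compound 1 to compound 2 (0.05 log units; within the scatter). The expected step is therefore a 1.1-fold higher number from compound 3 to compound 4 (0.06 log units; within the scatter), nothing beyond the scatter. The estimate for compound 4 in this assay is 45000 nM, with a range from 20000 nM to 100000 nM.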

Compound 4, half-maximal inhibitory concentration: 44800 nM
The estimate for compound 4 lay 1.0-fold (0.00 log units) above the measured number, and the stated range covers the measured number.
By their numbers in this assay, from the lowest: compounds 3, 4, 1 and 2 (each within the scatter of the next).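

Among the compounds shown here, compound 4 is the only one of the four to carry a halogen on the double-bonded nitrogen's phenyl group, yet in this assay there is a 1.1-fold higher number from compound 3 to compound 4 (0.06 log units; within the scatter) and a 1.2-fold lower number from compound 2 to compound 4 (0.07 log units; within the scatter) and a 1.0-fold lower number from compound 1 to compound 4 (0.02 log units; within the scatter) with no step leaving the scatter. Across amino and three different substituted phenyl groups, this position has so far shown no measurable response in this read-out. The compounds shown leave open whether a carboxylic acid, an aliphatic amine or a longer alkyl chain here would shift the number beyond the scatter. No measurement available here explains why these changes leave the number within the scatter.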